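Benzyl Substituent Swap on a Triazole Carboxamide Series

A few compounds are considered here, and "the series" means these few. Any claim that something is new, unique, unknown or untested is made for them only; others in the source may bear on it.

Compound 1 `C[C@H](NC(=O)c1nnn(Cc2ccc(C(F)(F)F)cc2)c1-c1ccccc1)c1ccc(C(=O)O)cc1`: > 10000 nM in a functional assay on CHO cells for antagonist activity at prostaglandin E2 receptor EP4 subtype (Homo sapiens), read by calcium flux, with a stated time of 15 min; a lower number here means a stronger inhibitor, a higher number a weaker inhibitor (a limit)
Compound 2 `C[C@H](NC(=O)c1c(C(F)(F)F)nnn1Cc1ccc(F)cc1)c1ccc(C(=O)O)cc1`: 2320 nM
Compound 3 `C[C@H](NC(=O)c1c(-c2ccccc2)nnn1Cc1ccc(F)cc1)c1ccc(C(=O)O)cc1`: 330 nM

Three compounds share a core and an acid-bearing side chain. Compound 1 reaches only (the limit of > 10000 nM in this assay, at which 1 of the 3 values shown sits), and that value is a limit rather than a number. Compound 2 gives 2320 nM. Among the measured compounds shown here, compound 3 gives 330 nM, the lowest of the two numbers, and the one measured step, a 7.0-fold lower number from compound 2 to compound 3 (0.85 log units; beyond the scatter), is the only change in this set that carries a number at both ends.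

Compound 4 `COc1cccc(Cn2nnc(-c3ccccc3)c2C(=O)N[C@@H](C)c2ccc(C(=O)O)cc2)c1` differs from compound 3 in one place: 3-methoxyphenyl in place of 4-fluorophenyl on a saturated chain carbon bound to an aromatic nitrogen. For the measured compounds named here, no measured step touches the benzyl group while keeping the rest fixed, so nothing here shows how this part of the molecule matters. Going by the values given here, the only exchange on the benzyl ring in the set, in compound 1, comes together with a second change and ends at a limit. With no guide, compound 4 is expected to sit near compound 3, with a 1.2-fold higher number from compound 3 to compound 4 (0.08 log units; within the scatter), and its estimated value is 400 nM, ranging from 100 nM to 2000 nM.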

Compound 4, half-maximal inhibitory concentration: 96.8 nM
Compound 4: middle estimate off by 4.1-fold (0.62 log units), on the high side; measured number outside the range, below it.
By their numbers in this assay, from the lowest: compound 4; then compound 3; then compound 2. At a limit, above all of these: compound 1.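

Among the compounds shown here, exchanging 4-fluorobenzyl for 3-methoxybenzyl gives a 3.4-fold lower number from compound 3 to compound 4 (0.53 log units; beyond the scatter) in this assay, the first measured step at this position with the rest of the molecule held fixed. It shows that the group on this saturated chain carbon bound to an aromatic nitrogen matters to the number, and that a single exchange on the benzyl ring can shift it beyond the scatter. Nothing measured in this set explains the shift.

On these data alone, the step changes both the substituent and its place on the ring, so it remains open whether the methoxy group, the loss of the fluorine or the new placement accounts for it. A 3-fluorobenzyl, a 4-methoxybenzyl or an unsubstituted benzyl group on the same core would separate these possibilities.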